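The source may hold more compounds than are shown below. What is called first, only, known or untested is meant among the compounds shown, and "the series" means these compounds.

Compound 2 `O=c1[nH]c(=O)n([C@H]2C[C@@H]3O[PH](O)(O)OC[C@H]3O2)cc1F` gives the lower of the two numbers seen so far: in a functional assay (Raji cells) for antiproliferative activity, with Homo sapiens as the target (a lower number here means a stronger inhibitor, a higher number a weaker inhibitor), compound 2 gives 0.164 ug/mL. Compound 1 `O=c1[nH]c(=O)n([C@H]2C[C@H](O)[C@@H](COP(=O)(O)O)O2)cc1Br` gives in this assay 26 ug/mL, a gap that is beyond the scatter; compound 1 differs from compound 2 in more than one place, so no single step can be read from that pair. Compound 3 `O=c1[nH]c(=O)n([C@H]2C[C@@H]3O[PH](O)(O)OC[C@H]3O2)cc1Br` carries bromo in place of fluoro on an aromatic carbon. Within the data shown here, no measured pair shows this change alone. The step is expected to raise the number by a 12-fold higher number from compound 2 to compound 3 (1.09 log units; beyond the scatter), beyond the scatter. Compound 3 is expected to give 2 ug/mL in this assay, within a range of 0.3 ug/mL to 15 ug/mL.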

Compound 3, concentration for 50% inhibition: 224 ug/mL
The estimate for compound 3 lay 110-fold (2.05 log units) below the measured number; the whole stated range lies below it.
By their numbers in this assay, from the lowest: compound 2; then compound 1; then compound 3.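

In this assay, among these compounds, the single change of bromo in place of fluoro on this aromatic carbon gives a 1400-fold higher number from compound 2 to compound 3 (3.14 log units; beyond the scatter) and is a large step, well beyond the scatter. Among the compounds shown here, it is the first step that can be read alone, and it shows that exchanging this one heavy atom on an otherwise unchanged core is enough to weaken inhibition strongly. Nothing given here accounts for the size of this step.

The compounds shown leave open how a chloro group, a methyl group or an amine on this carbon would compare. They also leave open whether the same exchange would give a similar step on the core of compound 1.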